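The compounds below may be only part of what the source reports. "The series", "measured", "known", "first", "only" and "open" are said of these compounds alone.

Compound 3 `CCCCOCNc1n[n+]([O-])c2ccccc2[n+]1[O-]` gives 6010 nM in a functional assay on PC-3 cells (Homo sapiens) for cytotoxicity, read by MTT assay, with a stated time of 72 h (on this read-out higher numbers stand for weaker inhibition and lower numbers for stronger inhibition), the second highest of three numbers. Compound 1 `COCNc1n[n+]([O-])c2ccccc2[n+]1[O-]` gives 4270 nM, and compound 2 `CC(C)CCOCNc1n[n+]([O-])c2ccccc2[n+]1[O-]` gives 7520 nM; the steps of a 1.4-fold higher number from compound 1 to compound 3 (0.15 log units; within the scatter), a 1.3-fold lower number from compound 2 to compound 3 (0.10 log units; within the scatter) and a 1.8-fold higher number from compound 1 to compound 2 (0.25 log units; within the scatter) all lie within the scatter. Compound 4 `CCCCCCCOCNc1n[n+]([O-])c2ccccc2[n+]1[O-]` differs from compound 3 by propyl in place of hydrogen on a saturated chain carbon, four bonds along the chain from an oxygen on a saturated carbon. The lengthening steps that bear on it are a 1.4-fold higher number from compound 1 to compound 3 (0.15 log units; within the scatter) and a 1.8-fold higher number from compound 1 to compound 2 (0.25 log units; within the scatter), both small and both toward higher numbers, so only a small step toward a higher number, if any, is expected for compound 4. Compound 4 is therefore estimated at 7500 nM, between 3500 nM and 16000 nM, a step of a 1.2-fold higher number from compound 3 to compound 4 (0.10 log units; within the scatter).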

Compound 4, half-maximal inhibitory concentration: 390 nM
Compound 4: middle estimate off by 19-fold (1.28 log units), on the high side; the measured number lies below the stated range.
By their numbers in this assay, from the lowest: compound 4; then compounds 1, 3 and 2 (each within the scatter of the next).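

Compounds 1, 2 and 3 lie within the scatter of one another, so chain length had shown no clear effect, but propyl in place of hydrogen at this position gives a 15-fold lower number from compound 3 to compound 4 (1.19 log units; beyond the scatter), a large step. The other two compounds show the same gap, with an 11-fold lower number from compound 1 to compound 4 (1.04 log units; beyond the scatter) and a 19-fold lower number from compound 2 to compound 4 (1.29 log units; beyond the scatter), so among these compounds the number falls sharply only with the heptyl chain of compound 4. No measurement given here accounts for this drop.

Going by these compounds, whether a longer chain keeps the low number remains open. So does the effect of an amine or a carboxylic acid at the chain end.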